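A few compounds are considered here, and "the series" means these few. Any claim that something is new, unique, unknown or untested is made for them only; others in the source may bear on it.

Compound 1 `COc1ccc(OC)c(/C=N/NC(=O)Nc2ccc(Oc3ccnc(-c4nncn4CCN(C)C)c3)c(F)c2)c1` carries the lowest of the three numbers in a functional assay on MKN-45 cells (Homo sapiens) for cytotoxicity, read by MTT assay, with a stated time of 72 h (on this read-out lower numbers stand for stronger inhibition and higher numbers for weaker inhibition), at 1510 nM, though its gaps to the other two stay within the scatter. Compound 2 `COc1ccc(/C=N/NC(=O)Nc2ccc(Oc3ccnc(-c4nncn4CCN(C)C)c3)c(F)c2)c(OC)c1` gives 1680 nM and compound 3 `CN(C)CCn1cnnc1-c1cc(Oc2ccc(NC(=O)N/N=C/c3ccc(O)c(Br)c3)cc2F)ccn1` gives 1860 nM; the steps of a 1.1-fold higher number from compound 1 to compound 2 (0.05 log units; within the scatter), a 1.2-fold higher number from compound 1 to compound 3 (0.09 log units; within the scatter) and a 1.1-fold higher number from compound 2 to compound 3 (0.04 log units; within the scatter) are all within the scatter. Compound 4 `COc1ccc(/C=N/NC(=O)Nc2ccc(Oc3ccnc(-c4nncn4CCN(C)C)c3)c(F)c2)cc1O` differs from compound 1 by 3-hydroxy-4-methoxyphenyl in place of 2,5-dimethoxyphenyl on a carbon with a double bond to nitrogen. The measured steps that bear on this change, swaps on the same carbon, are a 1.1-fold higher number from compound 1 to compound 2 (0.05 log units; within the scatter) and a 1.2-fold higher number from compound 1 to compound 3 (0.09 log units; within the scatter), neither beyond the scatter. No step beyond the scatter is therefore expected; the estimated change is a 1.1-fold higher number from compound 1 to compound 4 (0.05 log units; within the scatter). Compound 4 is expected at 1700 nM, with a range of 800 nM to 3600 nM.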

Compound 4, half-maximal inhibitory concentration: 2510 nM
Compound 4: the middle estimate sits 1.5-fold (0.17 log units) below what was measured; measured number inside the range.
By their numbers in this assay, from the lowest: compounds 1, 2, 3 and 4 (each within the scatter of the next).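

With 3-hydroxy-4-methoxyphenyl on the carbon with a double bond to nitrogen, a 1.7-fold higher number from compound 1 to compound 4 (0.22 log units; within the scatter) and a 1.5-fold higher number from compound 2 to compound 4 (0.17 log units; within the scatter) and a 1.3-fold higher number from compound 3 to compound 4 (0.13 log units; within the scatter) all stay within the scatter in this assay for this fourth substituted phenyl group. Across the four groups, with a hydroxy group (compounds 3 and 4) or without one (compounds 1 and 2), this position shows no step beyond the scatter. Nothing available gives a reason for these numbers. Still open, as far as these compounds go, is whether an amine or a carboxylic acid on this phenyl ring, or a longer chain in its place, would give a step beyond the scatter.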